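Nitro in place of methyl: what to expect

This account rests on a few compounds, and the source may have more. Where it says the series, first, only, none or still open, it means among the compounds named here.

- compound 1 `Cc1cc(Nc2ccc(C(=O)/C=C/c3ccc4ccccc4c3)cc2)n2nc(SCc3ccc(Cl)cc3)nc2n1` gives 570 nM
- compound 2 `Cc1ccc(CSc2nc3nc(C)cc(Nc4ccc(C(=O)/C=C/c5ccc6ccccc6c5)cc4)n3n2)cc1` gives 880 nM

In a functional assay on SW-620 cells (Homo sapiens) for cytotoxicity, read by MTT assay, with stated times of 4 h and 72 h, tested at 5 uM (a lower number here means a stronger inhibitor, a higher number a weaker inhibitor), compound 2 gives 880 nM and sits within the scatter of compound 1. The change to compound 3 `Cc1cc(Nc2ccc(C(=O)/C=C/c3ccc4ccccc4c3)cc2)n2nc(SCc3ccc([N+](=O)[O-])cc3)nc2n1` is nitro in place of methyl on an aromatic carbon and puts nitro in place of methyl on an aromatic carbon, para to a large group. For the measured compounds named here, the only measured step at this place is a 1.5-fold higher number from compound 1 to compound 2 (0.19 log units; within the scatter) and it stays within the scatter, so no step beyond the scatter is expected in this assay for nitro, a group not yet measured here. The expected step is a 1.3-fold lower number from compound 2 to compound 3 (0.11 log units; within the scatter) and it remains an estimate. Compound 3 is estimated at 680 nM (range 250 nM to 1800 nM).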

Compound 3, half-maximal inhibitory concentration: 1130 nM
For compound 3 the middle estimate is 1.7-fold (0.22 log units) below the measured one; measured number inside the range.
By their numbers in this assay, from the lowest: compounds 1, 2 and 3 (each within the scatter of the next).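

With (4-nitrobenzyl)sulfanyl in place of (4-methylbenzyl)sulfanyl, this assay shows a 1.3-fold higher number from compound 2 to compound 3 (0.11 log units; within the scatter), and nitro in place of chloro shows a 2.0-fold higher number from compound 1 to compound 3 (0.30 log units; within the scatter). Both steps lie within the scatter, so chloro, methyl and nitro at this place, para to a large group, cannot be told apart in this assay. No measurement at hand offers an explanation for this result. As far as these compounds go, whether an amine or a carboxylic acid at this place would give a step beyond the scatter remains open. So does the effect of a longer chain in place of the benzyl group.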